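Lengthening the Chain on the Amide Side

The compounds below may be only part of what the source reports. "The series", "measured", "known", "first", "only" and "open" are said of these compounds alone.

Three measured compounds share one core and differ only in the group that sits on a saturated chain carbon bound to an amide-type nitrogen. In a functional assay on HEK293 cells for positive allosteric modulation of metabotropic glutamate receptor 5 (Rattus norvegicus), read by fluorescence and calcium flux (on this read-out lower numbers stand for smaller maximal responses and higher numbers for larger maximal responses), compound 1 `CC(C)CNC(=O)c1ccc(C#Cc2cccc(F)c2)cn1` gives 58.2%. Compound 2 `CC(C)(O)CCNC(=O)c1ccc(C#Cc2cccc(F)c2)cn1` gives 61.9%, and compound 3 `CC1(CNC(=O)c2ccc(C#Cc3cccc(F)c3)cn2)COC1` gives 60.4%. On these numbers compound 3 stands second highest of the three, yet every comparison among them stays within the usual scatter: a number 3.7 percentage points higher from compound 1 to compound 2 (within the scatter), a number 2.2 percentage points higher from compound 1 to compound 3 (within the scatter), and a number 1.5 percentage points lower from compound 2 to compound 3 (within the scatter). Swapping isopropyl for a larger branched chain, for an oxetane-bearing group, or one of those for the other has not moved the maximal response beyond what repeat measurements would show anyway.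

Compound 4 `CC1(CCNC(=O)c2ccc(C#Cc3cccc(F)c3)cn2)COC1` has not yet been measured in this assay. It differs from compound 3 in one place: (3-methyloxetan-3-yl)methyl in place of 3-methyloxetan-3-yl on a saturated chain carbon bound to an amide-type nitrogen. Every measured step changes the group at this same place, and each was within the scatter, so the step from compound 3 to compound 4 is expected to be a small one as well, with no clear direction. The expected step is a number 0.4 percentage points lower from compound 3 to compound 4 (within the scatter), which stays inside the scatter. Compound 4 is therefore estimated to give 60%, with a likely range from 50% to 70%.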

Compound 4, largest response reached (reported as efficacy), in percent of the reference or control that the assay uses: 65.7%
Estimate against measurement, compound 4: 5.7 percentage points below; the measured number falls inside the stated range.
By their numbers in this assay, from the lowest: compounds 1, 3, 2 and 4 (each within the scatter of the next).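

Putting (3-methyloxetan-3-yl)methyl in place of 3-methyloxetan-3-yl extends the chain while keeping the oxetane ring, and in this assay this gives a number 5.3 percentage points higher from compound 3 to compound 4 (within the scatter) as its step. The two other comparisons with compound 4 read a number 3.8 percentage points higher from compound 2 to compound 4 (within the scatter) for the exchange of 1-hydroxy-1-methylethyl for 3-methyloxetan-3-yl on the same chain and a number 7.5 percentage points higher from compound 1 to compound 4 (within the scatter) for the exchange with isopropyl, and this last step is the largest seen so far at this place. Even so, all of them stay within the scatter, so this place on the chain now accepts a fourth group with no difference in maximal response that can be told apart from repeat variation, and no measured data are available that could explain the small differences.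

Still open, as far as these compounds go, is whether the same holds when an amine or a carboxylic acid stands at the end of this chain, or when the chain grows longer still, as in 3-(3-methyloxetan-3-yl)propyl. The compounds shown also leave open whether any group at this place can produce a step beyond the scatter.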